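The compounds below may be only part of what the source reports. "The series", "measured", "known", "first", "only" and "open" are said of these compounds alone.

Series notes. Compound 1 `CCCCOc1nc(C(C)(C)C)ccc1CNC(=O)C(C)c1ccc(NS(C)(=O)=O)c(F)c1`, compound 2 `CC(C)CCOc1nc(C(C)(C)C)ccc1CNC(=O)C(C)c1ccc(NS(C)(=O)=O)c(F)c1` and compound 3 `CCCCCSc1nc(C(C)(C)C)ccc1CNC(=O)C(C)c1ccc(NS(C)(=O)=O)c(F)c1` have been measured in an assay on cells for antagonist activity at transient receptor potential cation channel subfamily V member 1 (Homo sapiens), read by FLIPR and calcium flux, with a stated time of 6 min (on this read-out lower numbers stand for stronger inhibition and higher numbers for weaker inhibition), while compound 4 `CCCCCCSc1nc(C(C)(C)C)ccc1CNC(=O)C(C)c1ccc(NS(C)(=O)=O)c(F)c1` has not. In this assay compound 1 gives 0.9 nM, compound 2 gives 0.8 nM and compound 3 gives 3.1 nM.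

The change from compound 1 to compound 2, (methyl in place of hydrogen on a saturated chain carbon bound to two saturated chain carbons), produced a 1.1-fold lower number from compound 1 to compound 2 (0.05 log units; within the scatter). For the measured compounds named here, the change from compound 3 to compound 4, (methyl in place of hydrogen on a saturated chain carbon, five bonds along the chain from a sulfur), is the same kind of change: in both cases methyl replaces hydrogen on a saturated chain carbon, but in the first pair that carbon is bound to two saturated chain carbons, whereas in compound 4 it is five bonds along the chain from a sulfur. The two cores differ as well, namely (pentylsulfanyl in place of butoxy on an aromatic carbon). That core difference registered as a 3.4-fold higher number from compound 1 to compound 3 (0.54 log units; beyond the scatter) and as a 3.9-fold higher number from compound 2 to compound 3 (0.59 log units; beyond the scatter), so compound 3 has the highest number among the three measured compounds.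

Because the earlier step of a 1.1-fold lower number from compound 1 to compound 2 (0.05 log units; within the scatter) stayed within the scatter, the same kind of change on the core of compound 3 is expected to give a similarly small step, estimated as a 1.0-fold lower number from compound 3 to compound 4 (0.01 log units; within the scatter). The different surroundings of the added methyl and the different core are not covered by any measured pair, so the expected range is kept wide. Compound 4 is therefore estimated at 3 nM in this assay, with an expected span from 1.4 nM to 6.5 nM.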

Compound 4, inhibition constant: 1.5 nM
Compound 4: the middle estimate sits 2.0-fold (0.30 log units) above what was measured; the measured number falls inside the stated range.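

Carrying this methyl-for-hydrogen change from the core of compound 1 to the core of compound 3 gave two steps in this assay that cannot be told apart: the same change on two cores in this assay, a 1.1-fold lower number (0.05 log units; within the scatter) from compound 1 to compound 2 and a 2.1-fold lower number (0.32 log units; beyond the scatter) from compound 3 to compound 4, 1.8-fold (0.26 log units) apart, within the scatter of two such steps. Read alone, a 2.1-fold lower number from compound 3 to compound 4 (0.32 log units; beyond the scatter) lies beyond the scatter, while a 1.9-fold higher number from compound 2 to compound 4 (0.27 log units; within the scatter) and a 1.7-fold higher number from compound 1 to compound 4 (0.22 log units; within the scatter) both lie within it, so compound 4 cannot be separated from either oxygen-linked compound, unlike compound 3. For the compounds shown here, this is only one pair on each core, and the methyl enters at a different kind of chain carbon in each pair, so it shows agreement within the scatter for these compounds but not that the change transfers reliably, nor that a longer sulfur-linked chain generally gives a lower number.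

The compounds shown leave open whether a longer chain such as heptylsulfanyl would keep following the step from pentylsulfanyl to hexylsulfanyl, and how a branched chain such as isopentylsulfanyl would compare with the isopentyloxy of compound 2. They also leave open how an amine link in place of the oxygen or sulfur, carrying the same chains, would read in this assay.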